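Closing the glycine chain into a pyrrolidine ring

This account rests on a few compounds, and the source may have more. Where it says the series, first, only, none or still open, it means among the compounds named here.

Measured compounds:
- compound 1 `Cc1cc(C(=O)N2CCCCc3ccccc32)ccc1CNC(=O)NCC(=O)OC(C)C`: 140 nM
- compound 2 `Cc1cc(C(=O)N2CCCCc3ccccc32)ccc1CNC(=O)NCC(=O)N(C)C`: 58 nM
- compound 3 `CCN(CC)C(=O)[C@@H]1CCCN1C(=O)NCc1ccc(C(=O)N2CCCCc3ccccc32)cc1C`: 350 nM

These three compounds share one core and differ only in the group attached to a carbonyl carbon of the urea. In a functional assay on HEK293 cells for agonist activity at Vasopressin V2 receptor (Homo sapiens), read by a luciferase reporter and cAMP accumulation (a higher number here means that more compound is needed for the effect, a lower number that less compound is needed), compound 1 gives 140 nM, the second highest of the three numbers; its nearest neighbour is compound 2 and its furthest is compound 3.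

Compound 4 `CO[C@@H]1C[C@@H](C(=O)N(C)C)N(C(=O)NCc2ccc(C(=O)N3CCCCc4ccccc43)cc2C)C1` has not yet been measured. Compared with compound 1 it carries the change (2-(dimethylcarbamoyl)-4-methoxypyrrolidin-1-yl in place of ((isopropoxycarbonyl)methyl)amino on a carbonyl carbon).

Among the compounds with values here, two measured steps bear on this. Exchanging the isopropoxy of the ester for dimethylamino gave a 2.4-fold lower number from compound 1 to compound 2 (0.38 log units; beyond the scatter), so an amide at that end helps. Closing the chain into a pyrrolidine ring bearing a diethylcarbamoyl group gave a 2.5-fold higher number from compound 1 to compound 3 (0.40 log units; beyond the scatter), so the ring costs some potency. Within the data shown here, compound 4 combines a ring with a dimethylcarbamoyl group and adds a methoxy group whose effect no measured pair shows. The two known pulls roughly cancel, so compound 4 is expected to land near compound 1, with a 1.4-fold higher number from compound 1 to compound 4 (0.15 log units; within the scatter) as the estimated step. The estimate for compound 4 is 200 nM, within a range from 60 nM to 700 nM.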

Compound 4, half-maximal effective concentration: 4.7 nM
Compound 4: the middle estimate sits 43-fold (1.63 log units) above what was measured; the whole stated range lies above it.
By their numbers in this assay, from the lowest: compound 4; then compound 2; then compound 1; then compound 3.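

Compound 3 taken alone suggested that a ring on this carbonyl carbon costs potency, but in this assay compound 4 shows that a ring here can go with far less compound being needed, with a 30-fold lower number from compound 1 to compound 4 (1.47 log units; beyond the scatter) against the open-chain ester and a 12-fold lower number from compound 2 to compound 4 (1.09 log units; beyond the scatter) against the open-chain dimethylamide. Between the two ring compounds the change is a 74-fold lower number from compound 3 to compound 4 (1.87 log units; beyond the scatter) and so wider than any step among the first three compounds, which means that in this small set what the pyrrolidine carries counts for more than whether the chain is open or closed. No measurement shown here accounts for this gain.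

The step between the two ring compounds swaps diethylcarbamoyl for dimethylcarbamoyl and adds the methoxy at the same time, so the compounds shown cannot say which change carries the gain, or what the two defined stereocentres contribute. A pyrrolidine with dimethylcarbamoyl and no methoxy would separate these effects, and a hydroxy or a fluorine in the methoxy's place would test how specific that group is.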